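The source may hold more compounds than are shown below. What is called first, only, known or untested is meant among the compounds shown, and "the series" means these compounds.

Measured compounds:
compound 1 `CCn1c(-c2ccc(OCc3c(-c4c(Cl)cccc4Cl)noc3C(C)C)cc2)nc2ccc(C(=O)O)cc21` — 19.3 nM
compound 2 `CC(C)c1onc(-c2c(Cl)cccc2Cl)c1COc1ccc(-c2nc3ccc(C(=O)O)cc3n2CC(C)(C)C)cc1` — 24.8 nM
compound 3 `CCC(CC)n1c(-c2ccc(OCc3c(-c4c(Cl)cccc4Cl)noc3C(C)C)cc2F)nc2ccc(C(=O)O)cc21` — 69.3 nM

In an assay on isolated protein for agonist activity at Bile acid receptor (Homo sapiens), read by TR-FRET (a higher number here means that more compound is needed for the effect, a lower number that less compound is needed), compound 2 stands second highest of the three numbers: its gap to compound 1 is within the scatter, while compound 3 gives a clearly higher number. Compound 4 `CC(C)c1onc(-c2c(Cl)cccc2Cl)c1COc1ccc(-c2nc3ccc(C(=O)O)cc3n2-c2ccc(F)cc2)cc1` has not been measured; it differs from compound 2 by 4-fluorophenyl in place of neopentyl on an aromatic nitrogen.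

Within the data shown here, the one measured step at the same position is a 1.3-fold higher number from compound 1 to compound 2 (0.11 log units; within the scatter). That step did not move the number beyond the scatter. Among the measured compounds shown here, compound 3 is not joined to compound 2 by a single step, since it differs in two places, so its value shows only that a different branched group on that nitrogen together with an added fluorine went with a higher number. For the measured compounds named here, no measured pair covers the exchange of a saturated chain for a six-membered aromatic ring on this nitrogen, so the expectation rests on the single step above. A modest shift toward a higher number is expected, with wide uncertainty because the change in kind goes beyond a 1.3-fold higher number from compound 1 to compound 2 (0.11 log units; within the scatter). Compound 4 is therefore estimated at 40 nM, with a range of 15 nM to 120 nM. The expected step is a 1.6-fold higher number from compound 2 to compound 4 (0.21 log units; within the scatter).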

Compound 4, half-maximal effective concentration: 15.1 nM
Compound 4: middle estimate off by 2.6-fold (0.42 log units), on the high side; the range from low to high includes it.
By their numbers in this assay, from the lowest: compounds 4, 1 and 2 (each within the scatter of the next); then compound 3.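

In this assay, a six-membered aromatic ring on this aromatic nitrogen reads the same as the saturated chains, within the scatter: 4-fluorophenyl in place of neopentyl gives a 1.6-fold lower number from compound 2 to compound 4 (0.22 log units; within the scatter), and 4-fluorophenyl in place of ethyl gives a 1.3-fold lower number from compound 1 to compound 4 (0.11 log units; within the scatter). The earlier single-step comparison covered only saturated chains, so these steps extend the position's flat behaviour to a change in kind, from a chain with no ring to an aryl group, and ethyl, neopentyl and 4-fluorophenyl cannot be ordered by these numbers. No measurement here bears on why the number stays within the scatter across these groups.

On these data alone, the share of the fluorine remains open: plain phenyl, 4-chlorophenyl or 4-methoxyphenyl on this nitrogen would separate the ring from its substituent. Also open, as far as these compounds go, is whether the flat behaviour holds for groups carrying a heteroatom, such as a pyridine ring, or a chain ending in an amine or a carboxylic acid.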